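The compounds below may be only part of what the source reports. "The series", "measured", "known", "first", "only" and "open" are said of these compounds alone.

Measured so far in an assay on cells for inhibition of alkaline phosphatase, tissue-nonspecific isozyme (Homo sapiens), read by luminescence, with stated times of 7 min and 20 min; on this read-out higher numbers stand for weaker inhibition and lower numbers for stronger inhibition:
compound 1 `C=CCNc1nn2c(=O)cc(C(F)(F)F)nc2s1` gives 290 nM
compound 2 `CCCNc1nn2c(=O)cc(C(F)(F)F)nc2s1` gives 1440 nM

For the measured compounds named here, compound 2 stands at the higher of the two numbers; the only step, a 5.0-fold higher number from compound 1 to compound 2 (0.70 log units; beyond the scatter), is a modest rise. Compound 3 `CCCCNc1nn2c(=O)cc(C(F)(F)F)nc2s1` differs from compound 2 by methyl in place of hydrogen on a saturated chain carbon, three bonds along the chain from a nitrogen on an aromatic ring; the same difference, cut one bond further out, reads propyl to butyl. Going by the values given here, no measured step bears on lengthening the chain itself; the step from compound 1 to compound 2 changes saturation, not length. No step beyond the scatter is therefore expected in this assay, and the estimate for compound 3 is 1500 nM (range 500 nM to 4500 nM), meaning an expected step of a 1.0-fold higher number from compound 2 to compound 3 (0.02 log units; within the scatter).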

Compound 3, half-maximal inhibitory concentration: 880 nM
Estimate against measurement, compound 3: 1.7-fold (0.23 log units) above, and the stated range covers the measured number.
By their numbers in this assay, from the lowest: compound 1; then compounds 3 and 2 (each within the scatter of the next).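

Extending the saturated chain from propyl to butyl gives a 1.6-fold lower number from compound 2 to compound 3 (0.21 log units; within the scatter) in this assay, so this added methyl does not separate the two saturated chains. The vinyl-ended chain of compound 1 stays apart from butyl as well as from propyl, with a 3.0-fold higher number from compound 1 to compound 3 (0.48 log units; beyond the scatter) on this read-out. No supporting measurement on these compounds explains either step.

Still open, on these data alone, is whether a pentyl or longer chain stays level with compounds 2 and 3. Also open, as far as these compounds go, is how an alkyne-ended chain, a cyclopropylmethyl group or a terminal amine compares with the vinyl end of compound 1.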